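Swapping Hydroxy for Amino on a Short Side Chain

The source may report more compounds than this note shows. Statements on the series, on what has been measured and on what is new or still open speak of the compounds shown alone.

Among the measured compounds shown here, compound 2 `O=c1c2ccccc2c(-c2cccnc2)nn1CCO` holds the lower of the two numbers measured so far: in an assay on isolated protein (Oryctolagus cuniculus) with Thromboxane-A synthase (Homo sapiens) as the target, tested at 1 uM (a lower number here means less inhibition, a higher number more inhibition at the concentration tested (going by the name of the read-out)), compound 2 gives 69%. Compound 1 `O=c1c2ccccc2c(-c2cccnc2)nn1CCCCSc1ncccn1` gives 96% in this assay. For the measured compounds named here, the only measured step, a number 27 percentage points lower from compound 1 to compound 2 (beyond the scatter), came from hydroxy taking the place of 2-((pyrimidin-2-yl)sulfanyl)ethyl. Compound 3 `NCCn1nc(-c2cccnc2)c2ccccc2c1=O` differs from compound 2 in one way: amino in place of hydroxy on a saturated chain carbon, two bonds along the chain from an aromatic nitrogen. Going by the values given here, no measured step exchanges one of these small groups for the other, so the direction is unguided, and a step within the scatter is expected. Compound 3 is estimated at 66%, between 42% and 86%, an expected step of a number 3 percentage points lower from compound 2 to compound 3 (within the scatter).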

Compound 3, a percentage reported as inhibition, at one concentration (the size of the read-out at that concentration, not a potency): 29%
Compound 3: middle estimate off by 37 percentage points, on the high side; measured number below the stated range.
By their numbers in this assay, from the lowest: compound 3; then compound 2; then compound 1.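

At this chain end, exchanging hydroxy for amino is far from a neutral swap: in this assay it gives a number 40 percentage points lower from compound 2 to compound 3 (beyond the scatter), although the two groups match in heavy atoms, hydrogen-bond donors and acceptors. Set against the long sulfanyl chain, the drop widens to a number 67 percentage points lower from compound 1 to compound 3 (beyond the scatter), so a single atom at the end of the short chain can move this number strongly. Nothing measured here explains the loss.

On these data alone, it remains open how a methoxy group, a dimethylamino group or a carboxylic acid would fare at this chain end. Whether a longer chain ending in amino would recover inhibition is also unknown.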